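The compounds below may be only part of what the source reports. "The series", "measured", "known", "first", "only" and "open" are said of these compounds alone.

Compound 1 `C/C(=N\Nc1nc(-c2ccccc2)cs1)c1sc(C)nc1C` is the reference point of this small set. In a toxicity assay on THP-1 cells (Homo sapiens) for cytotoxicity, read by MTT assay (on this read-out higher numbers stand for weaker inhibition of growth and lower numbers for stronger inhibition of growth), compound 1 gives > 100 ug/mL, which is a limit of the assay rather than a number. For the measured compounds named here, compound 2 `C/C(=N\Nc1nc(-c2ccc(Br)cc2)cs1)c1sc(C)nc1C` is its one measured neighbour. In this assay compound 2 gives > 100 ug/mL, again a limit. The step from compound 1 to compound 2 is a step that the two limits leave unreadable from compound 1 to compound 2. Going by the values given here, both values sit at the limit of > 100 ug/mL in this assay, at which 2 of the 2 values shown sit, so no step in this set has a readable size. Compound 3 `C/C(=N\Nc1nc(-c2ccccc2)cs1)c1sc(-c2ccccc2)nc1C` differs from compound 1 by phenyl in place of methyl on an aromatic carbon. Among the compounds with values here, the bromo step is the only comparison at hand, and it offers neither size nor direction. For compound 3 in this assay the expectation is therefore a value near the same limit, estimated at 100 ug/mL with a range from 40 ug/mL to 250 ug/mL. The step from compound 1 to compound 3 is accordingly expected to be a number no higher from compound 1 to compound 3 (the limit leaves the size open), with no shift beyond the scatter foreseen.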

Compound 3, concentration for 50% growth inhibition: > 100 ug/mL
Compound 3 gave a limit, no number (the forecaster's own chance of this, stated with the estimate: 65%); the middle value lies on the limit itself.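

Compound 3, like compound 1 and compound 2, gives only a limit in this assay, so no step among them can be read: the limit of > 100 ug/mL in this assay, at which 3 of the 3 values shown sit.

The compounds shown leave open whether bromo in place of hydrogen or phenyl in place of methyl alters growth inhibition at all.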